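This account rests on a few compounds, and the source may have more. Where it says the series, first, only, none or still open, it means among the compounds named here.

Compound 1 `COc1cc(/C=C/C(=O)/C=C/c2cccc3ccccc23)ccc1OCc1cn(CCOc2cc(=O)oc3ccccc23)nn1`: 85%
Compound 2 `COc1cc(/C=C/C(=O)/C=C/c2cccc3ccccc23)ccc1OCc1cn(CCCCCOc2cc(=O)oc3ccccc23)nn1`: 40%

Within the data shown here, in a functional assay on COLO 205 cells (Homo sapiens) for inhibition, read by sulforhodamine B assay, with a stated time of 48 h, tested at 50 uM (a lower number here means less inhibition of growth, a higher number more inhibition of growth at the concentration tested), compound 1 gives 85%, the higher of the two numbers measured so far. Compound 2, at 40%, lies well below it, and that gap is beyond the usual scatter of repeated measurements.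

The next compound to be tested is compound 3 `COc1ccccc1/C=C/C(=O)/C=C/c1ccc(OCc2cn(CCOc3cc(=O)oc4ccccc34)nn2)c(OC)c1`, which has not yet been measured. It departs from compound 1 at a single place, carrying 2-methoxyphenyl in place of naphthalen-1-yl on a double-bonded chain carbon bound to a double-bonded chain carbon.

Among the measured compounds shown here, no measured pair shows what this exchange does in this assay, so any forecast of its size is uncertain. Compound 1, at 85%, leaves limited room for a rise, so a moderate fall is the more likely direction. The estimated change is a number 15 percentage points lower from compound 1 to compound 3 (beyond the scatter), which would be a drop somewhat beyond the scatter. For compound 3 the expected value is 70%, with an estimated range of 45% to 90%.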

Compound 3, percent growth inhibition at one concentration: 67%
Compound 3: the middle estimate sits 3 percentage points above what was measured, and the stated range covers the measured number.
By their numbers in this assay, from the lowest: compound 2; then compound 3; then compound 1.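

In this assay, among these compounds, the earlier compounds both carried naphthalen-1-yl at this position, so they gave no reading of what a change there does, and the exchange for 2-methoxyphenyl now gives a number 18 percentage points lower from compound 1 to compound 3 (beyond the scatter). The step is modest but real: the position accepts one six-membered aromatic ring in place of two, together with one added hydrogen-bond acceptor, at some cost, while compound 3 still reaches 67%. Nothing available accounts for the loss of growth inhibition, so the reason for this step remains unknown.

This single exchange removes one aromatic ring and adds a methoxy group at once, so the compounds shown cannot separate the two changes; an unsubstituted phenyl, a 2-hydroxyphenyl or a 4-methoxyphenyl group at the same place would be needed to tell them apart. They also leave open whether 2-methoxyphenyl would have a similar effect on the longer chain of compound 2, and how the compounds rank across a range of concentrations rather than at the single one tested.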